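The compounds below may be only part of what the source reports. "The series", "measured", "known", "first", "only" and "open" are said of these compounds alone.

Working notes on the series in an ADME assay on HeLa Rh cells (Homo sapiens) for cytotoxicity, read by microscopy; a lower number here means that less compound is tolerated, a higher number that more compound is tolerated.

Going by the values given here, compound 1 `COc1cc(CC(O)c2ccc(-c3ccc([N+](=O)[O-])cc3)cc2)c([N+](=O)[O-])cc1OC` gives 21000 nM in this assay, the higher of the two numbers so far. Among the compounds with values here, compound 2 `COc1cc(CC(O)c2ccc(-c3ccccc3F)cc2)c([N+](=O)[O-])cc1OC` gives 5000 nM in this assay; the step of a 4.2-fold lower number from compound 1 to compound 2 (0.62 log units; beyond the scatter) is the only measured change at this position. Compound 3 `COc1cc(CC(O)c2ccc(-c3ccccc3CO)cc2)c([N+](=O)[O-])cc1OC` is not yet measured in this assay. Relative to compound 1 the change is 2-(hydroxymethyl)phenyl in place of 4-nitrophenyl on an aromatic carbon.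

The step from compound 1 to compound 2 is the only one that bears on this change, and it carries the same leaving group at the same place, but the entering group differs, so it is taken as a rough guide only. On that basis a lower number than compound 1 is expected for compound 3, of a size near a 2.1-fold lower number from compound 1 to compound 3 (0.32 log units; beyond the scatter). For compound 3 the estimate in this assay is 10000 nM, with a range from 3500 nM to 30000 nM.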

Compound 3, half-maximal cytotoxic concentration: 24000 nM
Compound 3: middle estimate off by 2.4-fold (0.38 log units), on the low side; low and high end bracket the measured number.
By their numbers in this assay, from the lowest: compound 2; then compounds 1 and 3 (each within the scatter of the next).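

In this assay, a 1.1-fold higher number from compound 1 to compound 3 (0.06 log units; within the scatter) shows that the lower number of compound 2 does not follow simply from the loss of 4-nitrophenyl, since compound 3 also lacks that group yet stands within the scatter of compound 1. The group on the entering phenyl ring matters here, with a 4.8-fold higher number from compound 2 to compound 3 (0.68 log units; beyond the scatter) on hydroxymethyl in place of fluoro. No measurement at hand bears on the reason for this difference.

On these data alone, whether other groups in place of fluoro or hydroxymethyl, such as an amine or a carboxylic acid, also stay within the scatter of compound 1 remains open. Also open, as far as these compounds go, is whether a longer chain in place of hydroxymethyl would keep the number seen for compound 3.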